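The compounds below may be only part of what the source reports. "The series", "measured", "known", "first", "only" and "open" are said of these compounds alone.

In an ADME assay on Vero cells (Chlorocebus sabaeus) for cytotoxicity, read by neutral red uptake, tested at 394 ug/mL (on this read-out higher numbers stand for a weaker effect at the one concentration tested and lower numbers for a stronger effect), compound 1 `O=C1CSC(c2cccc(Cl)c2)N1CCN1CCCCC1` gives 45%, while compound 2 `O=C1CSC(c2ccccc2Cl)N1CCN1CCCCC1` gives 31%. Among these two numbers compound 2 stands lowest; its nearest neighbour is compound 1, and the step between them, a number 14 percentage points lower from compound 1 to compound 2 (beyond the scatter), lies beyond the usual scatter.

Compound 3 `O=C1CSC(c2ccc(Cl)cc2)N1CCN1CCCCC1` differs from compound 2 in a single place: 4-chlorophenyl in place of 2-chlorophenyl on a saturated ring carbon. Going by the values given here, the only measured step that bears on this change is the one already described, a number 14 percentage points lower from compound 1 to compound 2 (beyond the scatter), which shows that changing which chlorophenyl sits on that saturated ring carbon can shift the read-out by a modest amount. Among the compounds with values here, no measured compound carries the 4-chlorophenyl, so the direction for compound 3 is not settled by the data.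

On that basis compound 3 is expected to give 38%, with a range from 18% to 58%. The expected step, a number 7 percentage points higher from compound 2 to compound 3 (within the scatter), is estimated to be small and uncertain in direction.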

Compound 3, a percentage reported as activity, at one concentration (the size of the read-out at that concentration, not a potency): 28%
Compound 3: the middle estimate sits 10 percentage points above what was measured; measured number inside the range.
By their numbers in this assay, from the lowest: compounds 3 and 2 (each within the scatter of the next); then compound 1.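

In this assay, 4-chlorophenyl in place of 2-chlorophenyl on the saturated ring carbon gives a number 3 percentage points lower from compound 2 to compound 3 (within the scatter), so these two chlorophenyl placements cannot be told apart here. 4-chlorophenyl in place of 3-chlorophenyl gives a number 17 percentage points lower from compound 1 to compound 3 (beyond the scatter), which matches a number 14 percentage points lower from compound 1 to compound 2 (beyond the scatter) in direction and shows that, among these three compounds, the 3-chlorophenyl compound alone stands apart, with the weaker effect at the one concentration tested. No measurement shown here explains why this one placement differs.

As far as these compounds go, it remains open whether this separation is specific to chlorine or would also appear with 3-fluorophenyl or 3-methoxyphenyl at the same ring carbon. An unsubstituted phenyl there would show whether any chlorophenyl shifts the read-out at all.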